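From 2-hydroxyphenyl to 4-vinylphenyl on a sulfonyl sulfur

This account rests on a few compounds, and the source may have more. Where it says the series, first, only, none or still open, it means among the compounds named here.

In an ADME assay on HEK293 cells (Homo sapiens) for cytotoxicity, read by resazurin assay, with a stated time of 48 h (a lower number here means that less compound is tolerated, a higher number that more compound is tolerated), compound 1 (`O=S(=O)(Nc1ccc(-c2nc3ccccc3o2)cc1)c1cccs1`) reads > 100000 nM as a limit of the assay. Compound 2 (`O=S(=O)(Nc1ccc(-c2nc3ccccc3o2)cc1)c1ccccc1O`) reads > 100000 nM as a limit too. Compound 2 thus stands at the limit of > 100000 nM in this assay, at which 2 of the 2 values shown sit, and has no number of its own. Going by the values given here, the only measured change is a step that the two limits leave unreadable from compound 1 to compound 2 and it offers no size. Compound 3 (`C=Cc1ccc(S(=O)(=O)Nc2ccc(-c3nc4ccccc4o3)cc2)cc1`) has 4-vinylphenyl in place of 2-hydroxyphenyl on a sulfonyl sulfur, counted as 4-vinylphenyl in place of 2-hydroxyphenyl on a sulfonyl sulfur in this change. No step beyond the scatter is therefore expected in this assay and the expected step is an at least 1.2-fold lower number from compound 2 to compound 3 (0.09 log units; that floor lies within the scatter) here. Compound 3 is estimated at 80000 nM with 25000 nM to 100000 nM as the expected range.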

Compound 3, half-maximal cytotoxic concentration: > 100000 nM
Compound 3 was reported as a limit (the forecaster's own chance of this, stated with the estimate: 70%); middle value at least 1.2-fold (0.09 log units) from the limit.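

Going by these compounds alone, compound 1, compound 2 and compound 3 all sit at the same limit, so no step among them can be read: the limit of > 100000 nM in this assay, at which 3 of the 3 values shown sit.

The compounds shown leave open what any of these groups on the sulfonyl sulfur does to the tolerated concentration.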